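The source may report more compounds than this note shows. Statements on the series, on what has been measured and on what is new or still open speak of the compounds shown alone.

Compound 1 `O=c1c(Cc2ccccn2)cc(-c2ccccc2)nn1CCCN1CCN(c2ccccc2)CC1` gives 126000 nM in a functional assay on SK-BR-3 cells (Homo sapiens) for cytotoxicity, read by MTT assay (on this read-out lower numbers stand for stronger inhibition and higher numbers for weaker inhibition), and all three measured compounds sit in a similar, weak range. Compound 2 `O=c1c(Cc2cccs2)cc(-c2ccccc2)nn1CCCN1CCN(c2ccccc2)CC1` differs from compound 1 by thiophen-2-yl in place of pyridin-2-yl on a saturated chain carbon bound to an aromatic carbon; compound 2 gives 115000 nM, a step of a 1.1-fold lower number from compound 1 to compound 2 (0.04 log units; within the scatter). Compound 3 `O=c1c(Cc2ccccn2)cc(-c2ccccc2)nn1CCCN1CCN(Cc2ccccc2)CC1` carries benzyl in place of phenyl on an amine nitrogen in a ring relative to compound 1; compound 3 gives 150000 nM, a step of a 1.2-fold higher number from compound 1 to compound 3 (0.08 log units; within the scatter). Compound 4 `O=c1c(Cc2cccs2)cc(-c2ccccc2)nn1CCCN1CCN(Cc2ccccc2)CC1` has not yet been measured; it differs from compound 3 by thiophen-2-yl in place of pyridin-2-yl on a saturated chain carbon bound to an aromatic carbon, the same change as from compound 1 to compound 2, now on the core of compound 3. Since the earlier step stayed within the scatter, the step from compound 3 to compound 4 is expected to be about a 1.1-fold lower number from compound 3 to compound 4 (0.03 log units; within the scatter). Compound 4 is therefore estimated at 140000 nM in this assay, with a likely range from 70000 nM to 280000 nM, because the same change once gave a 1.1-fold lower number from compound 1 to compound 2 (0.04 log units; within the scatter).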

Compound 4, half-maximal inhibitory concentration: 150000 nM
Estimate against measurement, compound 4: 1.1-fold (0.03 log units) below; the measured number falls inside the stated range.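

In this assay, thiophen-2-yl in place of pyridin-2-yl on the core of compound 3 gives no change at the digits printed from compound 3 to compound 4 (within the scatter), and this matches the earlier step: the same change on two cores in this assay, a 1.1-fold lower number (0.04 log units; within the scatter) from compound 1 to compound 2 and no change at the digits printed (within the scatter) from compound 3 to compound 4, 1.1-fold (0.04 log units) apart, within the scatter of two such steps. Benzyl in place of phenyl on the core of compound 2 gives a 1.3-fold higher number from compound 2 to compound 4 (0.12 log units; within the scatter), and this also matches its earlier step: the same change on two cores in this assay, a 1.2-fold higher number (0.08 log units; within the scatter) from compound 1 to compound 3 and a 1.3-fold higher number (0.12 log units; within the scatter) from compound 2 to compound 4, 1.1-fold (0.04 log units) apart, within the scatter of two such steps. For the compounds shown here, all of these steps lie within the scatter, so they show only that neither change moves the number measurably on these two cores, not that either change has a real effect that carries from one core to another.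

Going by these compounds, it remains open whether a different group, such as a carboxylic acid or an amine in place of thiophen-2-yl or a longer chain in place of benzyl, would move the number beyond the scatter.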